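Benzoxaborole chalcones: carboxy for phenyl on cell growth

The compounds below may be only part of what the source reports. "The series", "measured", "known", "first", "only" and "open" are said of these compounds alone.

Measured so far in a functional assay on HCT-116 cells (Homo sapiens) for cytotoxicity, read by MTT assay, with a stated time of 48 h; on this read-out higher numbers stand for weaker inhibition and lower numbers for stronger inhibition:
- compound 1, `O=C(/C=C/c1ccc2c(c1)B(O)OC2)c1ccc(-c2ccccc2)cc1`, 9500 nM
- compound 2, `Cc1ccc(C(=O)/C=C/c2ccc3c(c2)B(O)OC3)cc1C`, 6100 nM
- compound 3, `COc1cccc(C(=O)/C=C/c2ccc3c(c2)B(O)OC3)c1`, 5000 nM

Compound 1 has the highest of the three numbers, but its gaps to compound 2 and to compound 3 both sit within the scatter, so no order among the three can be read from these data. Among the compounds with values here, no pair of measured compounds differs in a single place, so no measured step is available as a reference.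

Compound 4, `O=C(O)c1ccc(C(=O)/C=C/c2ccc3c(c2)B(O)OC3)cc1`, differs from compound 1 as follows: carboxy in place of phenyl on an aromatic carbon.

On the shared core, only variations of the aryl ketone substituent have been measured, all within the scatter of one another. A step in this assay from compound 1 to compound 4 is therefore expected to be modest, most likely toward a higher number, with no change beyond the scatter also plausible. Compound 4 is estimated at 16000 nM, range 5000 nM to 50000 nM, a step of a 1.7-fold higher number from compound 1 to compound 4 (0.23 log units; within the scatter) expected from compound 1.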

Compound 4, half-maximal inhibitory concentration: > 100000 nM
Compound 4: a limit, no number; the forecaster's own chance of this, stated with the estimate: 15%; middle value at least 6.2-fold (0.79 log units) away from the limit.
By their numbers in this assay, from the lowest: compounds 3, 2 and 1 (each within the scatter of the next). At a limit, above all of these: compound 4.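

Within the data shown here, on an aromatic carbon para to a large group, the earlier compounds offered no step to read. In this assay, carboxy in place of phenyl now gives an at least 10-fold higher number from compound 1 to compound 4 (1.02 log units; beyond the scatter), so this position does not tolerate every change, and a single replacement here can take the series out of the measurable range. The result for compound 4 is a limit and not a number, so the full size of the step stays unknown: the limit of > 100000 nM in this assay, at which 1 of the 4 values shown sits.

The compounds shown leave open whether the loss follows from the arrival of carboxy or from the departure of phenyl, since this one step changes both. A methyl ester, a primary amide or an amine on the same carbon, or a hydrogen there in place of any group, would help to separate the two.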